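This account rests on a few compounds, and the source may have more. Where it says the series, first, only, none or still open, it means among the compounds named here.

Compounds measured so far:
compound 1, `O=C1c2ccccc2C(=O)N1c1nc(-c2ccc(F)cc2)cs1`, 37200 nM in a functional assay on PC-3 cells (Homo sapiens) for antiproliferative activity, read by MTT assay, with a stated time of 48 h; a lower number here means a stronger inhibitor, a higher number a weaker inhibitor
compound 2, `O=C1c2ccc(F)cc2C(=O)N1c1nc(-c2ccc(F)cc2)cs1`, 39500 nM

Both were tested for antiproliferative activity in this assay. Within the data shown here, compound 2 holds the highest of the two numbers, and its nearest neighbour is compound 1; the one step between them, a 1.1-fold higher number from compound 1 to compound 2 (0.03 log units; within the scatter), introduces fluoro in place of hydrogen on an aromatic carbon of the shared core and lies within the scatter.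

Compound 3, `N#Cc1ccc(-c2csc(N3C(=O)c4ccc(F)cc4C3=O)n2)cc1`, has not been measured. It differs from compound 2 by cyano in place of fluoro on an aromatic carbon, in words: cyano in place of fluoro on an aromatic carbon, the same difference read one bond further out being 4-fluorophenyl to 4-cyanophenyl. Among the measured compounds shown here, no measured step touches this ring position or this exchange. For the measured compounds named here, the only step available, a 1.1-fold higher number from compound 1 to compound 2 (0.03 log units; within the scatter), concerns a different ring and was within the scatter, so it gives no direction for compound 3.

Compound 3 is therefore expected to land near compound 2, with an estimated step of a 1.1-fold lower number from compound 2 to compound 3 (0.05 log units; within the scatter). The estimate for compound 3 is 35000 nM, with a range from 15000 nM to 80000 nM.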

Compound 3, half-maximal inhibitory concentration: 43100 nM
Compound 3: middle estimate off by 1.2-fold (0.09 log units), on the low side; low and high end bracket the measured number.
By their numbers in this assay, from the lowest: compounds 1, 2 and 3 (each within the scatter of the next).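

In this assay, the change from 4-fluorophenyl to 4-cyanophenyl gives a 1.1-fold higher number from compound 2 to compound 3 (0.04 log units; within the scatter) and so shows that this exchange, on a six-membered aromatic ring of carbon only and para to a large group, leaves the number within the scatter. The earlier step, a 1.1-fold higher number from compound 1 to compound 2 (0.03 log units; within the scatter) on the other ring, said nothing about this position, but it too lies within the scatter, so neither of the two single changes shown separates its pair of compounds. No measurement shown bears on this result or offers an account of it.

On these data alone, what an amine, a carboxylic acid, a methoxy group or a plain hydrogen would do at this same position remains open, and so does whether any group there can move the number beyond the scatter. Also open, as far as these compounds go, is whether a chloro group in place of fluoro on the other ring, or a longer chain attached to the shared core, would separate from these three compounds, whose numbers all lie close together.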